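From Methylamino to a Cyano-Triazole on a Shared Core

A few compounds are considered here, and "the series" means these few. Any claim that something is new, unique, unknown or untested is made for them only; others in the source may bear on it.

In an ADME assay on microsomes from liver (Rattus norvegicus) for metabolic stability (a higher number here means faster removal of the compound, a lower number slower removal), compound 1 `CNc1nc(NC)nc(NC2(C#N)CCCCC2)n1` gives 210 mL/min/kg, the highest of the three numbers available. Compound 3 `CNc1nc(NC2(C#N)CCCC2)nc(-n2cncn2)n1` gives 43 mL/min/kg and compound 2 `CCCC(C#N)(CC)Nc1nc(NC)nc(-n2cncn2)n1` gives 29 mL/min/kg. Those two values lie within the scatter of each other, and both sit below compound 1 by more than the scatter.

Compound 4 `CNc1nc(NC2(C#N)CCCCC2)nc(-n2cnc(C#N)n2)n1` has not yet been measured. It differs from compound 1 in one place (3-cyano-1H-1,2,4-triazol-1-yl in place of methylamino on an aromatic carbon): 3-cyano-1H-1,2,4-triazol-1-yl stands in place of methylamino on an aromatic carbon, between two ring nitrogen atoms. The other methylamino group and the rest of compound 1 stay as they are.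

Going by the values given here, no measured pair isolates this change. Compound 2 and compound 3 carry a five-membered aromatic ring with 3 hetero atoms on that carbon, without the nitrile, but they also differ from compound 1 elsewhere. They are therefore only indirect guides, and the two low values they show are all the evidence there is. On that basis, the expected change in this assay is a fall beyond the scatter, estimated as a 4.7-fold lower number from compound 1 to compound 4 (0.67 log units; beyond the scatter). For compound 4 the estimated value is 45 mL/min/kg, with an expected range from 15 mL/min/kg to 120 mL/min/kg.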

Compound 4, clearance: 210 mL/min/kg
Compound 4: middle estimate off by 4.7-fold (0.67 log units), on the low side, and the stated range ends below it.
By their numbers in this assay, from the lowest: compounds 2 and 3 (each within the scatter of the next); then compounds 1 and 4 (each within the scatter of the next).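

In this assay, going by these compounds alone, setting 3-cyano-1H-1,2,4-triazol-1-yl in place of methylamino on this aromatic carbon gives no change at the digits printed from compound 1 to compound 4 (within the scatter) and so provides the first reading of a change at this position alone. The entering group brings a five-membered aromatic ring and a nitrile and lacks the hydrogen-bond donor of methylamino, yet this full exchange leaves the clearance read-out of the shared core unmoved, so the low numbers of compound 2 and compound 3 cannot be credited to a triazole-type ring at this carbon on the basis of this step. Nothing available explains why the exchange leaves the number in place.

Going by these compounds, it remains open whether the unsubstituted 1,2,4-triazole ring would behave the same way on the rest of compound 1, or whether the nitrile on the ring in compound 4 has any bearing on the number. Also open, on these data alone, is how a morpholine or a dimethylamino group would read at this carbon, and whether the remaining methylamino group or the other substituent of compound 4 governs its removal in this assay instead.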